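A few compounds are considered here, and "the series" means these few. Any claim that something is new, unique, unknown or untested is made for them only; others in the source may bear on it.

Compound 1 `Nc1nc(N)c2cc(C=O)ccc2n1` is a diaminoquinazoline bearing a formyl group, and in an assay for inhibition of Dihydrofolate reductase (Homo sapiens) (a lower number here means a less potent compound, a higher number a more potent compound, by a factor of ten per unit of this negative logarithm), compound 1 gives 5. That is the lowest of the three numbers in hand. The nearest is compound 2 `Nc1nc(N)c2c(Cl)c(N)ccc2n1`, which in this assay gives 6.18, a number beyond the scatter above compound 1. The furthest is compound 3 `Nc1nc(O)c2cc(S(=O)(=O)c3ccc(Cl)c(Cl)c3)ccc2n1`, which in this assay gives 7.12, again beyond the scatter above compound 1. No two of these compounds differ in one place only, so no single-point step can be read from them.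

Compound 4 `Nc1nc(N)c2cc(Cl)ccc2n1` is the compound still to be measured. It differs from compound 1 by a single change, (chloro in place of formyl on an aromatic carbon), chloro in place of formyl on an aromatic carbon. Among the measured compounds shown here, the three measured numbers offer no matched pair for this change, so the expectation rests on the shared core and on the position of compound 1 at the bottom of the set. The step from compound 1 to compound 4 in this assay is expected to be a modest gain, a number 0.80 log units higher from compound 1 to compound 4 (beyond the scatter). Compound 4 is therefore estimated to give 5.8 in this assay, within a range from 5 to 6.6.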

Compound 4, logarithm of the reciprocal of the active concentration, log(1/C): 5.4
Estimate against measurement, compound 4: 0.40 log units above; the measured number falls inside the stated range.
By their numbers in this assay, from the lowest: compound 1; then compound 4; then compound 2; then compound 3.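

In this assay, among the compounds shown here, chloro in place of formyl on an aromatic carbon gives a number 0.40 log units higher from compound 1 to compound 4 (beyond the scatter) as the first step in this set that can be read at a single place. The formyl, with its double bond and its hydrogen-bond acceptor, is therefore not needed at this position to hold the level of compound 1, and a lone chlorine atom, which has neither, does modestly better. Nothing available here accounts for the size of this step.

From the compounds shown here alone, whether an amine, a methyl or a carboxylic acid on this same carbon would move the number further remains open. Going by these compounds, compound 2 and compound 3 differ from compound 4 in more than one place, so the steps to them cannot be read, and whether the gain from chloro holds on their cores also remains open.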